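Peroxide ring epimer of a methylene-decalin acid

A few compounds are considered here, and "the series" means these few. Any claim that something is new, unique, unknown or untested is made for them only; others in the source may bear on it.

Measured so far:
compound 1 `C=C1CCC[C@H]2[C@](C)(CC[C@]3(C)CC[C@H]([C@@H](C)C(=O)O)OO3)[C@@H](C)CC[C@]12C` — 1170 nM
compound 2 `C=C1CCCC(C)(C)C1CC[C@]1(C)CC[C@@H]([C@@H](C)C(=O)O)OO1` — > 10000 nM

Among the compounds with values here, in a functional assay on EKVX cells (Homo sapiens) for inhibition (on this read-out higher numbers stand for weaker inhibition of growth and lower numbers for stronger inhibition of growth), compound 1 gives 1170 nM, the only actual number among the two values shown. For compound 2 the assay returns only a limit, > 10000 nM, which is the limit of > 10000 nM in this assay, at which 1 of the 2 values shown sits.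

Compound 3 `C=C1CCC[C@H]2[C@](C)(CC[C@]3(C)CC[C@@H]([C@@H](C)C(=O)O)OO3)[C@@H](C)CC[C@]12C` differs from compound 1 as follows: the two compounds have the same atoms and bonds and differ only in configuration as drawn: 1 of 7 stereo elements differ; a stereocentre at a saturated ring carbon is drawn R in compound 1 and S in compound 3. Within the data shown here, no step between measured compounds is available to calibrate this inversion, so its direction is open; a move within the usual scatter, in either direction, is the working assumption. Compound 3 is expected to give 1800 nM, between 450 nM and 8000 nM. The estimated step is a 1.5-fold higher number from compound 1 to compound 3 (0.19 log units; within the scatter).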

Compound 3, concentration for 50% growth inhibition: 1090 nM
For compound 3 the middle estimate is 1.7-fold (0.22 log units) above the measured one; the measured number falls inside the stated range.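

In this assay, inverting the stereocentre at the saturated ring carbon gives a 1.1-fold lower number from compound 1 to compound 3 (0.03 log units; within the scatter). Within the data shown here, this is the first step available for this inversion, and on this read-out the configuration drawn at this ring carbon does not separate the pair. The comparison bears on this single centre alone: the fact that compounds 1 and 3 differ only in the configuration as drawn

The compounds shown leave open how a methyl ester or a primary amide in place of the carboxylic acid would read in this assay. Going by these compounds, whether the inversion stays this small alongside such a group is also open.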